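The source may hold more compounds than are shown below. What is called first, only, known or untested is meant among the compounds shown, and "the series" means these compounds.

Compound 1 `CCSc1ccc(-c2nccc3[nH]c(C(C)(C)O)cc23)cc1`: 17200 nM
Compound 2 `COc1ccccc1-c1nccc2[nH]c(C(C)(C)O)cc12`: "not determined" (no result reported)
Compound 3 `CC(C)(O)c1cc2c(-c3ccc(-c4ccccc4)c(F)c3)nccc2[nH]1`: 9100 nM

In an ADME assay on U2OS cells (Homo sapiens) for cytotoxicity (on this read-out higher numbers stand for lower toxicity in this test and lower numbers for higher toxicity in this test), compound 1 gives 17200 nM, the larger of the two numbers recorded, while the gap to compound 3 at 9100 nM falls within the usual scatter, so the two cannot be told apart on this read-out. For compound 2 this assay gave no result. Compound 4 `CC(C)(O)c1cc2c(-c3ccc(C(F)(F)F)cc3)nccc2[nH]1` differs from compound 1 in one place: trifluoromethyl in place of ethylsulfanyl on an aromatic carbon. Among the compounds with values here, no measured pair in the set shows this change, so nothing directly supports a shift. The expected step of a 1.1-fold lower number from compound 1 to compound 4 (0.06 log units; within the scatter) is therefore none beyond the scatter. Compound 4 is estimated at 15000 nM in this assay, with a range from 6000 nM to 40000 nM.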

Compound 4, half-maximal cytotoxic concentration: 72300 nM
Beside the measured number, compound 4's estimate is 4.8-fold (0.68 log units) below it, outside the stated range (above it).
By their numbers in this assay, from the lowest: compounds 3 and 1 (each within the scatter of the next); then compound 4.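

On the aromatic carbon para to a large group, replacing ethylsulfanyl with trifluoromethyl moves the read-out in this assay by a 4.2-fold higher number from compound 1 to compound 4 (0.62 log units; beyond the scatter) in the direction of lower toxicity in this test. Within the data shown here, the earlier compounds offered no pair differing in one place, so this single pair is the first sign that the group at this position affects the read-out. Nothing measured here accounts for the shift.

From the compounds shown here alone, whether a nitrile, an amine or a longer chain at this position would move the number the same way remains open. So does whether the trifluoromethyl step would hold on a different core.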